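The source may report more compounds than this note shows. Statements on the series, on what has been measured and on what is new or still open speak of the compounds shown alone.

Compound 1 `N=C1NC(=O)/C(=C\c2c[nH]c3c(Br)cccc23)N1` and compound 3 `N=C1NC(=O)/C(=C\c2c[nH]c3cccc(Br)c23)N1` share the same atoms joined differently; the difference between the two cores is not broken down here. In an assay on CHO cells for displacement of a labelled ligand from 5-hydroxytryptamine receptor 5A (Homo sapiens) (on this read-out higher numbers stand for weaker inhibition and lower numbers for stronger inhibition), compound 1 gives 112 nM and compound 3 gives 123 nM, two numbers within the usual scatter of each other. Compound 2 `CN1C(=N)N/C(=C/c2c[nH]c3cccc(Br)c23)C1=O` carries methyl in place of hydrogen on an amide-type nitrogen in a ring and gives 1280 nM in this assay, so that a 10-fold higher number from compound 3 to compound 2 (1.02 log units; beyond the scatter). Compound 4 `CN1C(=N)NC(=O)/C1=C\c1c[nH]c2c(Br)cccc12` carries methyl in place of hydrogen on an amine nitrogen in a ring, the same kind of change, though here the methyl sits on an amine nitrogen in the ring rather than on an amide-type nitrogen. Because compound 3 to compound 2 moved as a 10-fold higher number from compound 3 to compound 2 (1.02 log units; beyond the scatter), a loss of similar size is expected for compound 4, an 8.0-fold higher number from compound 1 to compound 4 (0.91 log units; beyond the scatter), though with wide uncertainty. The value of compound 4 in this assay is estimated at 900 nM, likely between 250 nM and 3500 nM.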

Compound 4, inhibition constant: 1320 nM
For compound 4 the middle estimate is 1.5-fold (0.17 log units) below the measured one, and the stated range covers the measured number.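

In this assay the methyl weakens binding to a similar extent on both cores, with a 12-fold higher number from compound 1 to compound 4 (1.07 log units; beyond the scatter) matching the earlier step: the same change on two cores in this assay, a 10-fold higher number (1.02 log units; beyond the scatter) from compound 3 to compound 2 and a 12-fold higher number (1.07 log units; beyond the scatter) from compound 1 to compound 4, 1.1-fold (0.05 log units) apart, within the scatter of two such steps. In these two pairs the loss therefore carries over from one core to the other, even though the methyl sits on an amine nitrogen in one pair and on an amide-type nitrogen in the other. Two pairs do not show that it would carry over to further cores, and they do not explain why the methyl weakens binding.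

On these data alone, it remains open whether a larger group on these ring nitrogens, such as an ethyl or a longer chain, would behave like methyl. An acetyl group there is equally untested among the compounds shown.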